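Five-membered ring in place of pyridyl at the shared core

The source may hold more compounds than are shown below. What is called first, only, known or untested is meant among the compounds shown, and "the series" means these compounds.

Measured compounds:
compound 1, `CCN(c1ccc(C#N)c(Cl)c1)c1cc(-c2ccncc2)ccc1C`
compound 2, `N#Cc1ccc(N2CCc3cc(-c4cncnc4)ccc32)cc1C(F)(F)F`
compound 3, `CCN(c1cccc(-n2ccnc2)c1)c1ccc(C#N)c(C(F)(F)F)c1`

Among the measured compounds shown here, in a functional assay on VCaP cells (Homo sapiens) for antiproliferative activity, read by CCK-8 assay, with a stated time of 6 days (a higher number here means a weaker inhibitor, a lower number a stronger inhibitor), compound 1 gives 2900 nM, the only single number among the three. Compound 2 gives "not determined" (no result reported) in this assay, so no result is reported for it. Compound 3 reaches only > 30000 nM in this assay, which is a limit of the assay and not a number; (the limit of > 30000 nM in this assay, at which 1 of the 3 values shown sits). Compound 4, `CCN(c1ccc(C#N)c(Cl)c1)c1cc(-n2cccn2)ccc1C`, is not yet measured. It differs from compound 1 in one place: 1H-pyrazol-1-yl in place of pyridin-4-yl on an aromatic carbon. For the measured compounds named here, no step between two measured compounds is available for comparison. The step from compound 1 is expected to be small, at most slightly beyond the scatter, in the direction of weaker inhibition in this assay: a 1.6-fold higher number from compound 1 to compound 4 (0.19 log units; within the scatter). For compound 4 the estimate in this assay is 4500 nM, expected between 1500 nM and 14000 nM.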

Compound 4, half-maximal inhibitory concentration: 2340 nM
For compound 4 the middle estimate is 1.9-fold (0.28 log units) above the measured one; low and high end bracket the measured number.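

In this assay, the change at the carbon para to a methyl group gives a 1.2-fold lower number from compound 1 to compound 4 (0.09 log units; within the scatter). At this position on the core of compound 1, a five-membered aromatic ring with 2 hetero atoms therefore reads the same as a six-membered aromatic ring with 1 hetero atom. No measurement at hand bears on why the two rings read alike.

As far as these compounds go, it remains open whether a non-aromatic group, such as an amine or a carboxylic acid, would hold at this position. From the compounds shown here alone, whether the same ring change would carry over to other cores also remains open.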